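Replacing the aryl substituent on a ring amine nitrogen

A few compounds are considered here, and "the series" means these few. Any claim that something is new, unique, unknown or untested is made for them only; others in the source may bear on it.

Compound 1 `Nc1scc(CN2CCN(c3cc(Cl)cc(Cl)c3)CC2)c1C(=O)c1ccc(Cl)cc1`: -22%
Compound 2 `Nc1scc(CN2CCN(c3ccc(Cl)c(C(F)(F)F)c3)CC2)c1C(=O)c1ccc(Cl)cc1`: -12%
Compound 3 `Nc1scc(CN2CCN(c3ccc(C(F)(F)F)cc3)CC2)c1C(=O)c1cccc(C(F)(F)F)c1`: -11%

In a functional assay on CHO cells with adenosine receptor A1 (Homo sapiens) as the target, read by cAMP accumulation and immunoassay, with a stated time of 6 min, tested at 0.1 uM (on this read-out lower numbers stand for a stronger effect and higher numbers for a weaker effect at the one concentration tested), compound 2 stands second highest of the three numbers; its nearest neighbour is compound 3 and its furthest compound 1, both within the scatter. Compound 4 `Nc1scc(CN2CCN(c3ccccc3F)CC2)c1C(=O)c1ccc(Cl)cc1` differs from compound 2 in one place: 2-fluorophenyl in place of 4-chloro-3-(trifluoromethyl)phenyl on an amine nitrogen in a ring. Among the measured compounds shown here, the one measured step at this same position, a number 10 percentage points higher from compound 1 to compound 2 (within the scatter), stayed within the scatter, and compound 3 differs from compound 2 elsewhere as well, so no step to it is given. For the measured compounds named here, with the only relevant step so small, no movement beyond the scatter is expected: the estimated step is no change at the digits printed from compound 2 to compound 4 (within the scatter). The estimate for compound 4 in this assay is -12%, with a range from -26% to 2%.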

Compound 4, a percentage reported as activity, at one concentration (the size of the read-out at that concentration, not a potency): -1%
Estimate against measurement, compound 4: 11 percentage points below; measured number inside the range.
By their numbers in this assay, from the lowest: compounds 1, 2, 3 and 4 (each within the scatter of the next, the first and the last beyond it).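

In this assay the 2-fluorophenyl group on the ring amine nitrogen gives a number 11 percentage points higher from compound 2 to compound 4 (beyond the scatter) and a number 21 percentage points higher from compound 1 to compound 4 (beyond the scatter) in a single change, so this position can shift the read-out beyond the scatter, towards a weaker effect. The earlier step at this nitrogen did not show that. Nothing available explains the shift.

Because the entering group differs from both departing groups in its halogens and in where they sit, the contribution of each remains unresolved. As far as these compounds go, how a plain phenyl, or a phenyl carrying a methoxy group, would read at this nitrogen also stays open.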